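The compounds below may be only part of what the source reports. "The series", "measured", "known", "first", "only" and "open" are said of these compounds alone.

In a functional assay on HCT-116 cells (Homo sapiens) for cytotoxicity, read by sulforhodamine B assay, with a stated time of 72 h (a lower number here means a stronger inhibitor, a higher number a weaker inhibitor), compound 1 `CSC(=O)c1c(O[C@@H]2O[C@H](CO)[C@@H](O)[C@H](O)[C@H]2O)c(C)c(O)c(C)c1C(C)C` reads > 40000 nM, which is a limit. Compound 2 `CCc1c(C)c(O)c(C)c(O[C@@H]2O[C@H](CO)[C@@H](O)[C@H](O)[C@H]2O)c1C(=O)SC` reads > 40000 nM, also a limit, so it has no number to start from. For the measured compounds named here, the series so far stands at the limit of > 40000 nM in this assay, at which 2 of the 2 values shown sit. Compound 3 `CSC(=O)c1c(C)c(C)c(O)c(C)c1O[C@@H]1O[C@H](CO)[C@@H](O)[C@H](O)[C@H]1O` differs from compound 2 by hydrogen in place of methyl on a saturated chain carbon bound to an aromatic carbon, the same difference reading ethyl to methyl. Going by the values given here, the one measured step of similar kind is a step that the two limits leave unreadable from compound 1 to compound 2, so it gives no size to carry over. For compound 3 the expected step in this assay is a number no higher from compound 2 to compound 3 (the limit leaves the size open), with none expected beyond the scatter. Compound 3 is estimated at 40000 nM, within an expected range of 20000 nM to 80000 nM.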

Compound 3, half-maximal inhibitory concentration: > 40000 nM
Compound 3 gave a limit, no number; the forecaster's own chance of this, stated with the estimate: 90%; the middle value lies on the limit itself.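

No step can be read among compound 1, compound 2 and compound 3, since all three rest on the same limit: the limit of > 40000 nM in this assay, at which 3 of the 3 values shown sit.

In this assay, as far as these compounds go, how the isopropyl, ethyl and methyl groups rank remains open.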